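Replacing a Thiazole With an Amide on the Phenol Ring

The compounds below may be only part of what the source reports. "The series", "measured", "known", "first", "only" and "open" are said of these compounds alone.

Of the compounds shown here, two have been measured in an assay on isolated protein for inhibition of 2-Hydroxyacid oxidase 1 (Homo sapiens), with stated times of 30 min and 15 min; a lower number here means a stronger inhibitor, a higher number a weaker inhibitor. Compound 1 `CC(C)c1csc(-c2cccc(CN(C)c3ccc4[nH]nc(C(=O)O)c4c3)c2O)n1` gives 35 nM. Compound 2 `Cc1nc(-c2cccc(CNc3ccc4[nH]nc(C(=O)O)c4c3)c2O)sc1C` gives 25 nM in this assay. These two numbers fall within the usual scatter of each other, so the data do not separate the two compounds; compound 2 serves here only as the reference point for the next change.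

Compound 3 `CN(C)C(=O)c1cccc(CNc2ccc3[nH]nc(C(=O)O)c3c2)c1O` has not yet been measured in this assay. It differs from compound 2 in a single place: dimethylcarbamoyl in place of 4,5-dimethyl-1,3-thiazol-2-yl on an aromatic carbon. Among the compounds with values here, nothing measured so far tells how this part of the molecule affects inhibition, since compound 1 and compound 2 both carry a substituted thiazolyl group at that position and differ elsewhere.

Because compound 2 gives 25 nM and the exchange removes the ring-bearing group in favour of a smaller acyclic one, a step beyond the scatter toward weaker inhibition is expected, an 8.0-fold higher number from compound 2 to compound 3 (0.90 log units; beyond the scatter). Compound 3 is therefore estimated at 200 nM in this assay, with a plausible range from 60 nM to 800 nM.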

Compound 3, half-maximal inhibitory concentration: > 30000 nM
Compound 3 was reported as a limit (the forecaster's own chance of this, stated with the estimate: 5%); middle value at least 150-fold (2.17 log units) away from the limit.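

Within the data shown here, the exchange of 4,5-dimethyl-1,3-thiazol-2-yl for dimethylcarbamoyl on this aromatic carbon gives the first reading of this position in this assay, and it is a large one: an at least 1200-fold higher number from compound 2 to compound 3 (3.07 log units; beyond the scatter). From the compounds shown here alone, the value of compound 3, > 30000 nM, is a limit of the assay and not a number, so the true size of this step stays unknown: the limit of > 30000 nM in this assay, at which 1 of the 3 values shown sits. Compound 1 and compound 2 both carry a substituted thiazolyl group here, so they could not show what the new result does: in this one exchange, the dimethylcarbamoyl group does not stand in for the 4,5-dimethyl-1,3-thiazol-2-yl group, and inhibition at this position depends strongly on which of the two is present.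

The compounds shown leave open whether the loss follows from removing the ring or from bringing in the amide, a question that a phenyl or oxazol-2-yl group at the same carbon, or a methylcarbamoyl group, would help to settle. They also leave open how much the two methyl groups on the thiazole contribute, which an unsubstituted thiazol-2-yl group would address.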